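Trimming a Side Chain in a Lipoxygenase Inhibitor Series

The source may report more compounds than this note shows. Statements on the series, on what has been measured and on what is new or still open speak of the compounds shown alone.

Among the measured compounds shown here, compound 1 `CC(C)C(C#Cc1cccc(C(=O)NCc2ccccc2C(F)(F)F)c1)N(O)C(N)=O` gives 500 nM in an assay for inhibition of Polyunsaturated fatty acid 5-lipoxygenase (Homo sapiens), read by HPLC, with stated times of 15 min and 10 min (a lower number here means a stronger inhibitor, a higher number a weaker inhibitor), the higher of the two numbers known here. Compound 2 `CC(C#Cc1cccc(C(=O)NCCC(c2ccccc2)c2ccc(OC(F)(F)F)cc2)c1)N(O)C(N)=O` gives 110 nM in this assay, a lower number that lies beyond the scatter; it differs from compound 1 in two places, so its gap cannot be assigned to either. Compound 3 `C[C@H](C#Cc1cccc(C(=O)NCc2ccccc2C(F)(F)F)c1)N(O)C(N)=O` has not been measured. It differs from compound 1 by 1-(carbamoyl(hydroxy)amino)ethyl in place of 1-(carbamoyl(hydroxy)amino)-2-methylpropyl on a triple-bonded carbon. For the measured compounds named here, with no measured pair isolating this change, only a modest step toward a lower number is expected, near the edge of the scatter, as in a 1.7-fold lower number from compound 1 to compound 3 (0.22 log units; within the scatter). Compound 3 is therefore estimated at 300 nM, within 100 nM to 1000 nM.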

Compound 3, half-maximal inhibitory concentration: 600 nM
Estimate against measurement, compound 3: 2.0-fold (0.30 log units) below; low and high end bracket the measured number.
By their numbers in this assay, from the lowest: compound 2; then compounds 1 and 3 (each within the scatter of the next).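

Putting 1-(carbamoyl(hydroxy)amino)ethyl in place of 1-(carbamoyl(hydroxy)amino)-2-methylpropyl on a triple-bonded carbon gives a 1.2-fold higher number from compound 1 to compound 3 (0.08 log units; within the scatter) in this assay. Among the compounds shown here, this is the first comparison here that isolates a single place, and it shows that the two side chains read alike in this assay, with the rest of compound 1 unchanged. No supporting data bear on this result.

Still open, as far as these compounds go, is whether a longer chain or a phenyl ring at this position would shift the number beyond the scatter. From the compounds shown here alone, the role of the defined stereocentre in compound 3 also remains open.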